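Methylating a Phenol: Cytotoxicity in Two Related Series

The compounds below may be only part of what the source reports. "The series", "measured", "known", "first", "only" and "open" are said of these compounds alone.

Measured so far:
Compound 1, `COc1cc(OC)cc(-c2cc3ccccc3c(-c3cccc(O)c3)n2)c1`: 6770 nM
Compound 2, `COc1cc(OC)cc(-c2cc3ccccc3c(-c3cccc(OC)c3)n2)c1`: > 50000 nM
Compound 3, `COc1ccc(-c2cc3cc(C)ccc3c(-c3cccc(O)c3)n2)cc1OC`: 13500 nM

Of the compounds shown here, three have been tested in an ADME assay on MCF-10A cells (Homo sapiens) for cytotoxicity, read by CCK-8 assay and cell counting, with a stated time of 72 h; on this read-out lower numbers stand for stronger inhibition and higher numbers for weaker inhibition. Compound 1 `COc1cc(OC)cc(-c2cc3ccccc3c(-c3cccc(O)c3)n2)c1` gives 6770 nM in this assay. Compound 2 `COc1cc(OC)cc(-c2cc3ccccc3c(-c3cccc(OC)c3)n2)c1` reaches only a limit of the assay, > 50000 nM. Compound 2 arises from compound 1 by one change, (methyl in place of hydrogen on an oxygen on an aromatic ring), and this change gives an at least 7.3-fold higher number from compound 1 to compound 2 (0.86 log units; beyond the scatter); the measured number for compound 2 is itself only a limit, (the limit of > 50000 nM in this assay, at which 1 of the 3 values shown sits). Compound 3 `COc1ccc(-c2cc3cc(C)ccc3c(-c3cccc(O)c3)n2)cc1OC` gives 13500 nM in this assay, a value that lies within the scatter of compound 1. How the core of compound 3 differs from that of compound 1 is not broken down here.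

Compound 4 `COc1cccc(-c2nc(-c3ccc(OC)c(OC)c3)cc3cc(C)ccc23)c1` has not yet been measured. It arises from compound 3 by the same change, (methyl in place of hydrogen on an oxygen on an aromatic ring), at the same place as the change from compound 1 to compound 2. Among the measured compounds shown here, since the only measured example of this change, from compound 1 to compound 2, gave an at least 7.3-fold higher number from compound 1 to compound 2 (0.86 log units; beyond the scatter), a step of comparable size is expected here, a 6.7-fold higher number from compound 3 to compound 4 (0.82 log units; beyond the scatter), and a value that again reaches only the limit of this assay is the likeliest outcome. On that basis compound 4 is estimated at 90000 nM in this assay, expected to fall between 30000 nM and 300000 nM.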

Compound 4, half-maximal inhibitory concentration: > 50000 nM
Compound 4: only a limit was reported; the forecaster's own chance of this, stated with the estimate: 70%; the middle value does not contradict the limit.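

In this assay, the swap of 3-hydroxyphenyl to 3-methoxyphenyl gives an at least 3.7-fold higher number from compound 3 to compound 4 (0.56 log units; beyond the scatter), so the number rises on this second core as it did on the first, which here means weaker inhibition. Set side by side, the two cores read as follows: the same change on two cores in this assay, an at least 7.3-fold higher number (0.86 log units; beyond the scatter) from compound 1 to compound 2 and an at least 3.7-fold higher number (0.56 log units; beyond the scatter) from compound 3 to compound 4; the limit leaves it open whether they differ. As far as these compounds go, the direction of the step is thus shared by these two cores, but the true size of the step on either core stays unknown, and two cores are too few to make a rule for any other core: the limit of > 50000 nM in this assay, at which 2 of the 4 values shown sit.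

The compounds shown carry only a hydrogen or a methyl on this oxygen, which leaves open how a longer chain such as ethyl, or a chain ending in an amine, would read in this assay. Also open, from the compounds shown here alone, is how the hydroxy group would compare with an amine or a carboxylic acid placed directly on the same ring, and whether the same step would appear on a third core.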